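The compounds below may be only part of what the source reports. "The series", "measured", "known", "first", "only" and "open" are said of these compounds alone.

Compound 1 `O=C(/C=C/c1ccc2c(c1)B(O)OC2)c1ccco1`; compound 2 `Nc1cccc(C(=O)/C=C/c2ccc3c(c2)B(O)OC3)c1`; compound 3 `Nc1ccc(C(=O)/C=C/c2ccc3c(c2)B(O)OC3)cc1`, not yet measured.

In an ADME assay on L929 cells (Mus musculus) for cytotoxicity, read by resazurin assay, with a stated time of 72 h (a higher number here means a weaker inhibitor, a lower number a stronger inhibitor), compound 1 gives > 10 ug/mL, which is a limit of the assay and not a number. In this assay, going by the values given here, compound 2 gives 10 ug/mL, the only number among the values shown. The step of a number no higher from compound 1 to compound 2 (the limit leaves the size open) has no readable size, because the limit of > 10 ug/mL in this assay, at which 1 of the 2 values shown sits, is where compound 1 sits. Compound 3 differs from compound 2 by 4-aminophenyl in place of 3-aminophenyl on a carbonyl carbon. Among the compounds with values here, no measured step bears on this change, as the one step measured concerns a different group on the carbonyl carbon. For compound 3 a step of no change at the digits printed from compound 2 to compound 3 (within the scatter) is expected, within scatter. Compound 3 is thus expected at 10 ug/mL, between 4 ug/mL and 25 ug/mL.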

Compound 3, half-maximal inhibitory concentration: > 10 ug/mL
Compound 3: a limit, no number; the forecaster's own chance of this, stated with the estimate: 40%; the middle value lies on the limit itself.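

In this assay, going by these compounds alone, 4-aminophenyl in place of 3-aminophenyl on a carbonyl carbon gives a number no lower from compound 2 to compound 3 (the limit leaves the size open), the first reading on an exchange between these two aminophenyl groups at this place. Compound 3 gives a limit of the assay and not a number, and the series now sits mostly at that limit: the limit of > 10 ug/mL in this assay, at which 2 of the 3 values shown sit. The step between the limits of compound 1 and compound 3 cannot be read.

On these data alone, how far the 4-aminophenyl result lies from the 3-aminophenyl one remains open. Also open, as far as these compounds go, is what a 4-hydroxyphenyl or a 4-carboxyphenyl group on the same carbonyl carbon would give.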